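A Methyl Added to a Chain: What to Expect

The source may hold more compounds than are shown below. What is called first, only, known or untested is meant among the compounds shown, and "the series" means these compounds.

Compound 1, `C[C@@H]1CN(c2scnc2-c2nc3ccccc3[nH]2)CCN1C(=O)Cn1cnc2cccnc21`, gives 554 nM in an assay on blood for inhibition of C-X-C chemokine receptor type 3 (Homo sapiens), with a stated time of 30 min; a higher number here means a weaker inhibitor, a lower number a stronger inhibitor.
Compound 2, `CC[C@@H]1CN(c2scnc2-c2nc3ccccc3[nH]2)CCN1C(=O)Cn1cnc2cccnc21`, gives 851 nM in this assay.
Compound 3, `COc1ncc(-c2nc(C(F)(F)F)sc2N2CCN(C(=O)Cn3cnc4cccnc43)[C@H](C)C2)cn1`, gives 158 nM in this assay.

Compound 4, `CCOc1ncc(-c2nc(C(F)(F)F)sc2N2CCN(C(=O)Cn3cnc4cccnc43)[C@H](C)C2)cn1`, has not yet been measured. It arises from compound 3 by one change: methyl in place of hydrogen on a saturated chain carbon bound to an oxygen on an aromatic ring. The same kind of change has been tried once before among these compounds, going from compound 1 to compound 2, where it reads (methyl in place of hydrogen on a saturated chain carbon bound to a saturated ring carbon). That step gave a 1.5-fold higher number from compound 1 to compound 2 (0.19 log units; within the scatter). The surroundings are not identical, though: in the earlier pair the carbon that receives the methyl is bound to a saturated ring carbon, whereas in the new pair it is bound to an oxygen on an aromatic ring, so the two are the same kind of change rather than the same change. Compound 3 and compound 1 also sit on different cores, and the difference between the two cores is not broken down here.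

Compound 3 has the lowest number of the three measured compounds, and its nearest neighbour is compound 1. Within the data shown here, with only one earlier example, a small step is the most that can be expected from compound 3 to compound 4 in this assay, about a 1.3-fold higher number from compound 3 to compound 4 (0.12 log units; within the scatter), resting on the modest step seen from compound 1 to compound 2, a 1.5-fold higher number from compound 1 to compound 2 (0.19 log units; within the scatter). Compound 4 is therefore estimated at 210 nM, most likely between 90 nM and 480 nM.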

Compound 4, half-maximal inhibitory concentration: 48 nM
Compound 4: the middle estimate sits 4.4-fold (0.64 log units) above what was measured; the whole stated range lies above it.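

In this assay, extending the methoxy group of the 2-methoxypyrimidin-5-yl to an ethoxy group gives a 3.3-fold lower number from compound 3 to compound 4 (0.52 log units; beyond the scatter), so on this core the added methyl goes with a stronger inhibitor. Set beside the earlier case, the same kind of change does not carry over as one fixed step, since it goes with a clearly stronger inhibitor on one core but not on the other: the same change on two cores in this assay, a 1.5-fold higher number (0.19 log units; within the scatter) from compound 1 to compound 2 and a 3.3-fold lower number (0.52 log units; beyond the scatter) from compound 3 to compound 4, 5.1-fold (0.70 log units) apart, beyond the scatter of two such steps. This does not show what separates the two results: the methyl enters on a carbon bound to a saturated ring carbon in one pair and on a carbon bound to an oxygen on an aromatic ring in the other, and the cores differ as well, so two pairs cannot tell the effect of the site from the effect of the core.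

The compounds shown leave open whether the gain continues along the chain on the oxygen, as a propoxy group or a longer chain would test. They also leave open whether a different group at that place, such as an amine, would give a similar result, and whether a branched chain such as isopropoxy would.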